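The compounds below may be only part of what the source reports. "The series", "measured", "known", "first", "only" and "open" are said of these compounds alone.

Measured so far in a functional assay on the whole organism with Rattus norvegicus as the target (on this read-out higher numbers stand for an effect only at larger amounts of compound and lower numbers for an effect already at smaller amounts), are these compounds:
- compound 1 `CCN(CCNC(=O)c1cc(Cl)c(N)cc1OC)Cc1ccccc1OC` at 10 mg/kg
- compound 2 `CCN(CCNC(=O)c1cc(Cl)c(N)cc1OC)Cc1cccc(OC)c1` at 1 mg/kg
- compound 3 `CCN(CCNC(=O)c1cc(Cl)c(N)cc1OC)Cc1ccccc1Cl` at 10 mg/kg

Compound 3 stands level with compound 1, and together they hold the highest of the three numbers. In compound 4 `CCN(CCNC(=O)c1cc(Cl)c(N)cc1OC)Cc1ccc(F)cc1` the 4-fluorophenyl stands in place of the 2-chlorophenyl on a saturated chain carbon bound to an amine nitrogen 4-fluorophenyl in place of 2-chlorophenyl on a saturated chain carbon bound to an amine nitrogen and the rest is unchanged. Two measured changes at this place are large: a 10-fold lower number from compound 1 to compound 2 (1.00 log units; beyond the scatter) and a 10-fold higher number from compound 2 to compound 3 (1.00 log units; beyond the scatter) in the same assay. The exchange of chloro for methoxy gave no change at the digits printed from compound 1 to compound 3 (within the scatter) and so the two groups named with a 2 read alike. Going by the values given here, compound 4 carries neither of them, but no fluoro compound has been measured. A lower number than for compound 3 is therefore expected, though probably not the full size of a 10-fold higher number from compound 2 to compound 3 (1.00 log units; beyond the scatter) in reverse. The expected change is a 3.3-fold lower number from compound 3 to compound 4 (0.52 log units; beyond the scatter) in this assay as an estimate only. For compound 4 the estimated value is 3 mg/kg with an expected range from 1 mg/kg to 10 mg/kg on this reading.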

Compound 4, dose for half-maximal effect: 0.2 mg/kg
The estimate for compound 4 lay 15-fold (1.18 log units) above the measured number, outside the stated range (below it).
By their numbers in this assay, from the lowest: compound 4; then compound 2; then compounds 1 and 3 (each within the scatter of the next).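

In this assay, going by these compounds alone, the aryl group on a saturated chain carbon bound to an amine nitrogen proves to reach further than the earlier compounds showed: 4-fluorophenyl gives a 5.0-fold lower number from compound 2 to compound 4 (0.70 log units; beyond the scatter), so the 3-methoxyphenyl of compound 2 no longer marks the low end of the series. Measured against the two groups that read alike, the same position gives a 50-fold lower number from compound 3 to compound 4 (1.70 log units; beyond the scatter) and a 50-fold lower number from compound 1 to compound 4 (1.70 log units; beyond the scatter), both large steps and wider than any seen among the first three compounds. Nothing available explains why this exchange has so large an effect.

The compounds shown leave open whether the lower number goes with the fluoro group itself or with its place on the ring, since both differ from every earlier compound. A 4-chlorophenyl, a 4-methoxyphenyl or an unsubstituted phenyl at this position would bear on that question.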